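Aryl sulfamate series: amino substituent on the aryl amide

The source may report more compounds than this note shows. Statements on the series, on what has been measured and on what is new or still open speak of the compounds shown alone.

Measured compounds:
- compound 1 `CN(C)CCN(CCN(C)C)c1cccc(C(=O)N2CCc3ccc(OS(N)(=O)=O)cc3C2)c1`: 17.1%
- compound 2 `CCN(Cc1ccccc1)Cc1ccc(S(=O)(=O)N2CCc3ccc(OS(N)(=O)=O)cc3C2)cc1`: 31%
- compound 3 `CCN(Cc1ccc(Br)cc1)c1ccc(C(=O)N2CCc3ccc(OS(N)(=O)=O)cc3C2)cc1`: 95.9%

In an assay on HEK293 cells for inhibition of Steryl-sulfatase (Homo sapiens), tested at 1 uM (on this read-out higher numbers stand for a stronger effect at the one concentration tested and lower numbers for a weaker effect), compound 1 gives 17.1%, the lowest of the three numbers; compound 2 lies nearest, beyond the scatter, and compound 3 furthest, also beyond the scatter. Compound 4 `CC(C)CCN(CCC(C)C)c1cccc(C(=O)N2CCc3ccc(OS(N)(=O)=O)cc3C2)c1` has not been measured. It differs from compound 1 in one place: diisopentylamino in place of bis(2-(dimethylamino)ethyl)amino on an aromatic carbon.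

Going by the values given here, no step between measured compounds is directly comparable. Because compound 3 gives 95.9% with a different amino group on its aryl ring, an upward step is expected, of moderate size. The step estimated from compound 1 to compound 4 is a number 37.9 percentage points higher from compound 1 to compound 4 (beyond the scatter). Compound 4 is expected to give 55%, in the range 25% to 85%.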

Compound 4, a percentage reported as inhibition, at one concentration (the size of the read-out at that concentration, not a potency): 75.9%
Compound 4: middle estimate off by 20.9 percentage points, on the low side; low and high end bracket the measured number.
By their numbers in this assay, from the lowest: compound 1; then compound 2; then compound 4; then compound 3.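

Going by these compounds alone, on an aromatic carbon meta to a large group, diisopentylamino in place of bis(2-(dimethylamino)ethyl)amino gives the first readable step in this assay, a large one: a number 58.8 percentage points higher from compound 1 to compound 4 (beyond the scatter). The two groups match in heavy-atom count and differ in their carbon and nitrogen content, so heavy-atom count alone does not separate them. Nothing at hand bears on the cause of this step. Going by these compounds, whether the step follows the loss of the dimethylamino nitrogens or the gain of the isopentyl chains stays open. An amine carrying one 2-(dimethylamino)ethyl arm and one isopentyl arm would separate the two.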